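This account rests on a few compounds, and the source may have more. Where it says the series, first, only, none or still open, it means among the compounds named here.

Measured in a physicochemical assay for solubility, using the shake flask method, in phosphate buffer, with a stated time of 90 min, at pH 6.8; a lower number here means a less soluble compound, a higher number a more soluble compound:
- Compound 1 `O=C(/C=C(/C=C/c1ccc(O)cc1)NCCCO)/C=C/c1ccc(O)cc1`: 137000 nM
- Compound 2 `COc1cc(/C=C/C(=O)/C=C(/C=C/c2ccc(O)c(OC)c2)NCCCO)ccc1O`: 25400 nM
- Compound 3 `COCCNC(=C\C(=O)/C=C/c1ccc(O)cc1)/C=C/c1ccc(O)cc1`: 37500 nM

Among these three, compound 3 at 37500 nM cannot be told apart from compound 2 at 25400 nM, as the two values lie within the usual scatter of each other. Compound 1 stands clearly higher, at 137000 nM.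

The next compound is compound 4 `O=C(/C=C(/C=C/c1ccc(O)cc1)NCCO)/C=C/c1ccc(O)cc1`. Its difference from compound 3 is small: hydrogen in place of methyl on an oxygen on a saturated carbon. Hydrogen stands in place of methyl on an oxygen on a saturated carbon, so 2-methoxyethyl becomes 2-hydroxyethyl.

Within the data shown here, no measured pair shows exactly this change. The closest guide is a 3.7-fold lower number from compound 1 to compound 3 (0.56 log units; beyond the scatter), a modest step in which methoxy stands in place of hydroxymethyl on a saturated chain carbon. Compound 4 reverses part of that change by restoring a hydroxy end to the chain, although the chain does not match that of compound 1. A step of similar direction and somewhat smaller or equal size is therefore expected in this assay, but it rests on this single comparison. The estimated change is a 2.7-fold higher number from compound 3 to compound 4 (0.43 log units; beyond the scatter). For compound 4 the expected value is 100000 nM, with an estimated range from 45000 nM to 220000 nM.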

Compound 4, solubility: 38700 nM
Compound 4: middle estimate off by 2.6-fold (0.41 log units), on the high side; measured number below the stated range.
By their numbers in this assay, from the lowest: compounds 2, 3 and 4 (each within the scatter of the next); then compound 1.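

In this assay, hydrogen in place of methyl on the oxygen, turning 2-methoxyethyl into 2-hydroxyethyl, makes no difference that can be read (a 1.0-fold higher number from compound 3 to compound 4 (0.01 log units; within the scatter)), so at this chain end the methoxy and the hydroxy cannot be told apart. Compound 1 carries one more hydroxymethyl-bearing chain carbon than compound 4, and that change gives a clear step (a 3.5-fold lower number from compound 1 to compound 4 (0.55 log units; beyond the scatter)), much like the earlier one (a 3.7-fold lower number from compound 1 to compound 3 (0.56 log units; beyond the scatter)); among compounds 1, 3 and 4, then, the higher number goes with the chain of compound 1 and not simply with having a hydroxy end. No measurement in hand explains why this is so.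

A methoxy end on the longer chain of compound 1 would show whether the end group matters there, as it does not on the shorter chain. On these data alone, how a still longer chain, or an amine or a carboxylic acid at the chain end, would behave in this assay remains open.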